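Fluoro in Place of Hydrogen: an Expected Shift

The compounds below may be only part of what the source reports. "The series", "measured", "known", "first", "only" and "open" are said of these compounds alone.

For the measured compounds named here, compound 2 `Cc1ccc(-c2cc(-c3ccccc3)[nH]n2)cc1` gives 1510 nM in an assay on mitochondria from brain for inhibition of Amine oxidase [flavin-containing] A (Bos taurus), read by fluorescence (a higher number here means a weaker inhibitor, a lower number a stronger inhibitor), the highest of the two numbers measured so far; its nearest neighbour, compound 1 `Clc1ccc(-c2cc(-c3ccc(Cl)cc3)[nH]n2)cc1`, gives 2.04 nM in this assay, a gap well beyond the scatter. Compound 3 `Cc1ccc(-c2cc(-c3ccc(F)cc3)[nH]n2)cc1` differs from compound 2 by fluoro in place of hydrogen on an aromatic carbon. Going by the values given here, no measured pair shows this change, so the size of the step is uncertain. The step of a 3.8-fold lower number from compound 2 to compound 3 (0.58 log units; beyond the scatter) is expected to be modest, toward a lower number. Compound 3 is estimated at 400 nM, within 100 nM to 1500 nM.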

Compound 3, half-maximal inhibitory concentration: 2290 nM
Compound 3: the middle estimate sits 5.7-fold (0.76 log units) below what was measured, and the stated range ends below it.
By their numbers in this assay, from the lowest: compound 1; then compounds 2 and 3 (each within the scatter of the next).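

Fluoro in place of hydrogen on this aromatic carbon, para to a large group, gives a 1.5-fold higher number from compound 2 to compound 3 (0.18 log units; within the scatter) in this assay. For the compounds shown here, this is the first measured pair for the change, and at this position it leaves fluoro and hydrogen indistinguishable in this assay. Nothing at hand bears on why the two read alike. Going by these compounds, whether a methoxy group, an amine or a carboxylic acid on this same carbon would shift the number stays open. So does whether fluoro would read the same way on a core other than that of compound 2.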